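A Fluoro Step from Compound 1 to Compound 4

The compounds below may be only part of what the source reports. "The series", "measured", "known", "first", "only" and "open" are said of these compounds alone.

Measured in an ADME assay on SH-SY5Y cells (Homo sapiens) for cytotoxicity, read by MTT assay, with a stated time of 72 h; a higher number here means a weaker inhibitor, a lower number a stronger inhibitor:
- Compound 1 `O=C(CN1CCN(C(=O)c2ccccc2)CC1)N1CCN(CCCc2c[nH]c3ccccc23)CC1`: > 200000 nM (a limit, not a number)
- Compound 2 `COc1ccc(C(=O)N2CCN(CC(=O)N3CCN(CCCc4c[nH]c5ccccc45)CC3)CC2)cc1`: 148000 nM
- Compound 3 `O=C(CN1CCN(C(=O)c2cccc(Br)c2)CC1)N1CCN(CCCc2c[nH]c3ccccc23)CC1`: 80500 nM

Compound 1 gives > 200000 nM, and this value is a limit of the assay rather than a number. Compound 4 `O=C(CN1CCN(C(=O)c2ccccc2)CC1)N1CCN(CCCc2c[nH]c3ccc(F)cc23)CC1` differs from compound 1 by a single change, (fluoro in place of hydrogen on an aromatic carbon), in which 1H-indol-3-yl becomes 5-fluoro-1H-indol-3-yl. For the measured compounds named here, no measured step covers this place in the molecule. The nearest evidence comes from substitution on an aromatic carbon elsewhere. Bromo in place of hydrogen gave an at least 2.4-fold lower number from compound 1 to compound 3 (0.39 log units; beyond the scatter), and methoxy in place of hydrogen gave an at least 1.3-fold lower number from compound 1 to compound 2 (0.13 log units; that floor lies within the scatter). The remaining comparison gave a 1.8-fold lower number from compound 2 to compound 3 (0.26 log units; within the scatter). The first two steps are only floors, since both start from a limit, and neither involves fluoro. A small move toward a lower number is therefore expected, possibly none beyond the scatter, and a second limit reading remains quite possible. The expected step is an at least 1.3-fold lower number from compound 1 to compound 4 (0.12 log units; that floor lies within the scatter). For compound 4 the estimated value is 150000 nM. The expected range for compound 4 runs from 70000 nM to 260000 nM.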

Compound 4, half-maximal inhibitory concentration: 146000 nM
Beside the measured number, compound 4's estimate is 1.0-fold (0.01 log units) above it; low and high end bracket the measured number.
By their numbers in this assay, from the lowest: compounds 3, 4 and 2 (each within the scatter of the next). At a limit, above all of these: compound 1.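

In this assay, the change from 1H-indol-3-yl to 5-fluoro-1H-indol-3-yl is the only one shown on this part of the molecule, and compound 4 gives a true number, 146000 nM. Fluoro in place of hydrogen on this aromatic carbon gives an at least 1.3-fold lower number from compound 1 to compound 4 (0.13 log units; that floor lies within the scatter), so the substitution can be described only by a floor, and that floor does not establish a change. The reference reading for compound 1 is a limit of the assay and not a number, which leaves the true size of the step unknown: the limit of > 200000 nM in this assay, at which 1 of the 4 values shown sits.

How large the fluoro step really is remains open, as does whether fluoro would read the same on another aromatic carbon of the same ring, given that the compounds shown carry it at this one place only. Also open, going by these compounds, is how this assay would respond to a chloro, an amine or a carboxylic acid at this place, or to a longer chain joining the 1H-indol-3-yl group to the rest of the molecule.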